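The source may report more compounds than this note shows. Statements on the series, on what has been measured and on what is new or still open speak of the compounds shown alone.

Compound 1 `COc1ncnc2c1c(-c1ccsc1)cn2[C@@H]1O[C@H](CO)[C@@H](O)[C@H]1O` gives 120 nM in a functional assay on HCT-116 cells (Homo sapiens), read by MTT assay, with a stated time of 72 h; on this read-out higher numbers stand for weaker inhibition and lower numbers for stronger inhibition.
Compound 2 `Cc1ncnc2c1c(-c1cc3ccccc3o1)cn2[C@@H]1O[C@H](CO)[C@@H](O)[C@H]1O` gives only a limit, > 20000 nM, in this assay.
Compound 3 `COc1ncnc2c1c(-c1ccccc1)cn2[C@@H]1O[C@H](CO)[C@@H](O)[C@H]1O` gives only a limit, > 20000 nM, in this assay.

Compound 3 thus stands at the limit of > 20000 nM in this assay, at which 2 of the 3 values shown sit, and its true number is not known. Compound 4 `COc1ncnc2c1c(-c1cc3ccccc3o1)cn2[C@@H]1O[C@H](CO)[C@@H](O)[C@H]1O` differs from compound 3 by 1-benzofuran-2-yl in place of phenyl on an aromatic carbon. Going by the values given here, the only measured step, an at least 160-fold higher number from compound 1 to compound 3 (2.22 log units; beyond the scatter), concerns a different change and so does not bear on this one. Among the compounds with values here, compound 2 carries the same 1-benzofuran-2-yl group yet differs from compound 4 elsewhere, so no measured step covers the move. Compound 4 is therefore expected to stay at the limit as well, with an estimate of 20000 nM (range 5000 nM to 60000 nM). This estimate means an expected step of a number no higher from compound 3 to compound 4 (the limit leaves the size open), that is, no change beyond the scatter.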

Compound 4, half-maximal inhibitory concentration: 13800 nM
The estimate for compound 4 lay 1.4-fold (0.16 log units) above the measured number; the measured number falls inside the stated range.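

This position now has its first exact number for a group other than thiophen-3-yl: with 1-benzofuran-2-yl in place of thiophen-3-yl, the step is a 120-fold higher number from compound 1 to compound 4 (2.06 log units; beyond the scatter). Among the compounds shown, only thiophen-3-yl gives a low number here. With 1-benzofuran-2-yl in place of phenyl, the step is an at least 1.4-fold lower number from compound 3 to compound 4 (0.16 log units; that floor lies within the scatter). With methoxy in place of methyl, the step is an at least 1.4-fold lower number from compound 2 to compound 4 (0.16 log units; that floor lies within the scatter). As far as these compounds go, both of these steps start at a limit, so their full size remains unknown.

From the compounds shown here alone, how thiophen-2-yl or furan-3-yl would fare at this position remains open. So does the effect of an amine in place of the methoxy group.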